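The source may hold more compounds than are shown below. What is called first, only, known or untested is meant among the compounds shown, and "the series" means these compounds.

Measured compounds:
compound 1 `COc1cc2nc(N3CCN(C(=O)OCc4ccccc4)CC3)nc(N)c2cc1OC` — 63000 nM
compound 2 `COc1cc2nc(N3CCN(S(=O)(=O)c4ccc(Cl)cc4)CC3)nc(N)c2cc1OC` — 23000 nM

In a functional assay on PC-3 cells (Homo sapiens) for inhibition (on this read-out higher numbers stand for weaker inhibition and lower numbers for stronger inhibition), compound 2 gives 23000 nM, while compound 1 gives 63000 nM, so compound 2 holds the lower of the two numbers. Among the compounds with values here, the only measured step, a 2.7-fold lower number from compound 1 to compound 2 (0.44 log units; beyond the scatter), exchanged the whole group on the ring nitrogen. Compound 3 `COc1cc2nc(N3CCN(S(=O)(=O)c4ccc(Br)cc4)CC3)nc(N)c2cc1OC` differs from compound 2 by bromo in place of chloro on an aromatic carbon. Within the data shown here, no measured step swaps one halogen for another, so the one step at hand bears on it only loosely. A change expected to stay within the scatter is a 1.2-fold lower number from compound 2 to compound 3 (0.06 log units; within the scatter). Compound 3 is accordingly estimated at 20000 nM, with a range from 8000 nM to 50000 nM.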

Compound 3, half-maximal inhibitory concentration: 20000 nM
The estimate for compound 3 equals the measured number at the digits printed, within the range that was stated.
By their numbers in this assay, from the lowest: compounds 3 and 2 (each within the scatter of the next); then compound 1.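

In this assay, the halogen on this aromatic carbon proved interchangeable, as chloro and bromo stay within the scatter of each other: a 1.2-fold lower number from compound 2 to compound 3 (0.06 log units; within the scatter). A second halogenated sulfonyl group also keeps its distance from the benzyloxycarbonyl group on the ring nitrogen, with a 3.2-fold lower number from compound 1 to compound 3 (0.50 log units; beyond the scatter). Nothing at hand explains either step. Still open, from the compounds shown here alone, is whether an amine or a carboxylic acid on the same aromatic carbon would move the number, and whether a plain phenylsulfonyl group would stay within the scatter of compound 2 and compound 3.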